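Swapping the aryl group on the amine-linked carbon of compound 3

This account rests on a few compounds, and the source may have more. Where it says the series, first, only, none or still open, it means among the compounds named here.

Measured compounds:
compound 1, `C=C1CC[C@@H]2[C@](C)(CNCc3ccc(OC)cc3)[C@H](O)CC[C@@]2(C)[C@@H]1/C=C/C1=CCOC1=O`, 750 nM
compound 2, `C=C1CC[C@@H]2[C@](C)(CNCc3cccc(OC)c3)[C@H](O)CC[C@@]2(C)[C@@H]1/C=C/C1=CCOC1=O`, 780 nM
compound 3, `C=C1CC[C@@H]2[C@](C)(CNCc3ccc([N+](=O)[O-])cc3)[C@H](O)CC[C@@]2(C)[C@@H]1/C=C/C1=CCOC1=O`, 1340 nM

In a functional assay on BMMC cells (Mus musculus, strain C57BL/6) for inhibition, with stated times of 5 days and 48 h (a lower number here means a stronger inhibitor, a higher number a weaker inhibitor), compound 3 gives 1340 nM, the highest number of the three, yet its separation from compound 1 and from compound 2 stays within the scatter, so no order among them can be claimed. Compound 4, `C=C1CC[C@@H]2[C@](C)(CNCc3ccc4c(c3)CC=N4)[C@H](O)CC[C@@]2(C)[C@@H]1/C=C/C1=CCOC1=O`, differs from compound 3 by a group of 9 heavy atoms (8 carbon, 1 nitrogen; one five-membered non-aromatic ring with 1 hetero atom, one six-membered aromatic ring of carbon only) in place of a group of 9 heavy atoms (6 carbon, 1 nitrogen, 2 oxygen; one six-membered aromatic ring of carbon only), on a saturated chain carbon bound to an amine nitrogen. The measured steps that bear on this are the changes of the aryl group at the same place: a 1.8-fold higher number from compound 1 to compound 3 (0.25 log units; within the scatter) and a 1.7-fold higher number from compound 2 to compound 3 (0.24 log units; within the scatter), and also a 1.0-fold higher number from compound 1 to compound 2 (0.02 log units; within the scatter). All three are within the scatter, suggesting that varied aryl groups on this carbon give similar numbers. Among the measured compounds shown here, no measured compound carries a five-membered non-aromatic ring with 1 hetero atom, so the new group is untested. Compound 4 is therefore expected to show a 1.4-fold lower number from compound 3 to compound 4 (0.15 log units; within the scatter), a step not beyond the scatter. The estimate for compound 4 in this assay is 950 nM, with a range from 400 nM to 2300 nM.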

Compound 4, half-maximal inhibitory concentration: 550 nM
Beside the measured number, compound 4's estimate is 1.7-fold (0.24 log units) above it, and the stated range covers the measured number.
By their numbers in this assay, from the lowest: compounds 4, 1, 2 and 3 (each within the scatter of the next, the first and the last beyond it).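

In this assay, among the compounds shown here, the group with the five-membered non-aromatic ring gives the first step on this saturated chain carbon that lies beyond the scatter, a 2.4-fold lower number from compound 3 to compound 4 (0.39 log units; beyond the scatter), whereas the earlier aryl changes all stayed within it. Against the two methoxyphenyl groups the same kind of replacement stays within the scatter, a 1.4-fold lower number from compound 2 to compound 4 (0.15 log units; within the scatter) and a 1.4-fold lower number from compound 1 to compound 4 (0.13 log units; within the scatter), so the new group is separated only from the 4-nitrophenyl group, and the position still tolerates these aryl groups with modest differences at most. Nothing available explains this step.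

The compounds shown leave open whether the five-membered ring itself contributes, since an unsubstituted phenyl group offers no comparison here. They also leave open how a carboxylic acid on the aromatic ring or a longer chain on the amine nitrogen would read in this assay.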